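Series notes: the step from compound 2 to compound 3

A few compounds are considered here, and "the series" means these few. Any claim that something is new, unique, unknown or untested is made for them only; others in the source may bear on it.

Measured so far, in a functional assay on cells (Rhabdomyosarcoma cell, Homo sapiens) for cytotoxicity; on this read-out lower numbers stand for stronger inhibition and higher numbers for weaker inhibition:
compound 1 `FC(F)(F)c1ccc(C(c2ccccc2)N2CCN(c3ncnc4c3cnn4-c3ccccc3)CC2)cc1` gives > 25000 nM, a limit of the assay.
compound 2 `c1ccc(-c2ccc(C(c3ccccc3)N3CCN(c4ncnc5c4cnn5-c4ccccc4)CC3)cc2)cc1` gives > 25000 nM, again a limit of the assay.

Compound 2 therefore stands only at a limit in this assay; no number is known for it, and both shown values sit at the same limit, as the limit of > 25000 nM in this assay, at which 2 of the 2 values shown sit, records. For the measured compounds named here, the one measured step, a step that the two limits leave unreadable from compound 1 to compound 2, runs between two limits and has no readable size or direction.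

Compound 3 `c1ccc(C(c2ccccn2)N2CCN(c3ncnc4c3cnn4-c3ccccc3)CC2)cc1` differs from compound 2 by pyridin-2-yl in place of 4-phenylphenyl on a saturated chain carbon bound to an amine nitrogen in a ring and an aromatic carbon. No measured step touches the saturated chain carbon that carries this change, and the single step that is known is unreadable, so nothing in the shown data points toward a stronger or weaker result in this assay. The expectation is that compound 3 stays at the limit, with no step beyond the scatter. The estimated step is a step that the limit leaves unreadable from compound 2 to compound 3, expected to remain within the scatter. Compound 3 is expected to give 30000 nM in this assay, with a range from 10000 nM to 100000 nM.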

Compound 3, half-maximal inhibitory concentration: > 25000 nM
Compound 3: only a limit was reported; the forecaster's own chance of this, stated with the estimate: 75%; the middle value lies beyond the limit too.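

No step among compound 1, compound 2 and compound 3 can be read in this assay, because each gives a limit of the assay and not a number: the limit of > 25000 nM in this assay, at which 3 of the 3 values shown sit.

The compounds shown leave open whether any group on the saturated chain carbon can bring a numerical value in this assay, and how large the effect of each replacement is.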